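The compounds below may be only part of what the source reports. "The series", "measured", "known", "first", "only" and "open" are said of these compounds alone.

Working notes on the series. In a functional assay on HeLa cells (Homo sapiens) for cytotoxicity, read by cell counting, with a stated time of 4 days (on this read-out higher numbers stand for weaker inhibition and lower numbers for stronger inhibition), compound 2 `Nc1ccc(/C=C2\SC(=O)N(Cc3ccc(F)cc3)C2=O)cc1` gives 186000 nM, the highest of the three numbers in hand. Compound 1 `Nc1ccc(/C=C2\SC(=O)N(Cc3ccc(C(F)(F)F)cc3)C2=O)cc1` gives 96000 nM, and the step of a 1.9-fold higher number from compound 1 to compound 2 (0.29 log units; within the scatter) is within the scatter. Compound 3 `C=C(Br)C(=O)Nc1ccc(/C=C2\SC(=O)N(Cc3ccc(F)cc3)C2=O)cc1` gives 2000 nM, and the step of a 93-fold lower number from compound 2 to compound 3 (1.97 log units; beyond the scatter) is large. Compound 4 `CN1C(=O)S/C(=C\c2ccc(N)cc2)C1=O` differs from compound 2 by hydrogen in place of 4-fluorophenyl on a saturated chain carbon bound to an amide-type nitrogen in a ring. For the measured compounds named here, no measured step touches this place; the step from compound 1 to compound 2 alters the 4-fluorophenyl only at its fluorine and stays within the scatter, while the large step to compound 3 sits on the aromatic nitrogen and does not bear here. For compound 4 the expected step is a 1.2-fold higher number from compound 2 to compound 4 (0.07 log units; within the scatter), no more than the scatter. In this assay compound 4 is therefore estimated at 220000 nM, within 70000 nM to 700000 nM.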

Compound 4, half-maximal inhibitory concentration: 97000 nM
The estimate for compound 4 lay 2.3-fold (0.36 log units) above the measured number; measured number inside the range.
By their numbers in this assay, from the lowest: compound 3; then compounds 1, 4 and 2 (each within the scatter of the next).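

With the 4-fluorophenyl replaced by hydrogen on the saturated chain carbon bound to an amide-type nitrogen in a ring, this assay shows a 1.9-fold lower number from compound 2 to compound 4 (0.28 log units; within the scatter). The earlier steps shown here altered only the fluorine-bearing substituent, whereas this one removes the entire aromatic ring and still stays within the scatter, so at this level of the read-out the number does not depend on that ring. No measured evidence accounts for this result.

From the compounds shown here alone, whether the same change holds alongside the (1-bromoethenyl)carbonyl of compound 3 remains open. Also open, going by these compounds, is how an amine, a carboxylic acid or a longer chain at this place would read.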